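The compounds below may be only part of what the source reports. "The series", "measured", "known", "first", "only" and "open" are said of these compounds alone.

Measured so far:
Compound 1 `COc1ccc(C2C(C#N)=C(N)N(c3cc(OC)c(OC)c(OC)c3)C3=C2C(=O)CC(C)(C)C3)cc1`: 11%
Compound 2 `COc1cc(N2C(N)=C(C#N)C(/C=C/c3ccccc3)C3=C2CC(C)(C)CC3=O)cc(OC)c1OC`: 30%

In a functional assay on Ehrlich cells (Mus musculus) for cytotoxicity, tested at 50 ug/mL (on this read-out lower numbers stand for a weaker effect and higher numbers for a stronger effect at the one concentration tested), compound 2 gives 30%, the higher of the two numbers measured; compound 1 gives 11%. Among the measured compounds shown here, the only measured step, a number 19 percentage points higher from compound 1 to compound 2 (beyond the scatter), changed the group on the same saturated ring carbon that is altered here. Compound 3 `COc1cc(N2C(N)=C(C#N)C(c3ccc(OC)c4ccccc34)C3=C2CC(C)(C)CC3=O)cc(OC)c1OC` differs from compound 2 by 4-methoxynaphthalen-1-yl in place of 2-phenylethenyl on a saturated ring carbon. For the measured compounds named here, no measured step covers this exact swap, so the direction is open; the one known step shows that the group at this carbon can move the read-out by a modest amount. Compound 3 is therefore expected to land near compound 2, with a number 5 percentage points lower from compound 2 to compound 3 (within the scatter) estimated as small, giving an estimate of 25% within 5% to 50%.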

Compound 3, a percentage reported as activity, at one concentration (the size of the read-out at that concentration, not a potency): 40%
For compound 3 the middle estimate is 15 percentage points below the measured one; the measured number falls inside the stated range.
By their numbers in this assay, from the lowest: compound 1; then compounds 2 and 3 (each within the scatter of the next).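

In this assay, putting 4-methoxynaphthalen-1-yl in place of 2-phenylethenyl on the saturated ring carbon gives a number 10 percentage points higher from compound 2 to compound 3 (within the scatter) and so does not separate these two groups. Putting 4-methoxynaphthalen-1-yl in place of 4-methoxyphenyl gives a number 29 percentage points higher from compound 1 to compound 3 (beyond the scatter) and makes it the second group at this carbon to stand clear of compound 1. No measurement here explains these differences. Still open, on these data alone, is how this carbon responds to a group with no aromatic ring, such as a methyl group or a carboxylic acid. Also open, as far as these compounds go, is what a naphthalen-1-yl group without the methoxy would give.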